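Hydrogen in Place of tert-Butoxycarbonyl: Compound 4 Foreseen

A few compounds are considered here, and "the series" means these few. Any claim that something is new, unique, unknown or untested is made for them only; others in the source may bear on it.

Compound 1, `CC(C)(C)OC(=O)CN1CCc2c(sc(NC(=O)Nc3ccc(Cl)cc3)c2C(N)=O)C1`, gives > 25000 nM in a functional assay (strain AB) with Danio rerio as the target, read by microscopy, with a stated time of 1 h; a higher number here means that more compound is needed for the effect, a lower number that less compound is needed.
Compound 2, `CCC(O)c1cc2c(cc1NC(=O)Nc1ccc(Cl)cc1)OCCO2`, gives > 25000 nM in this assay.
Compound 3, `CCN1CCc2c(sc(NC(=O)Nc3ccc(Cl)cc3)c2C#N)C1`, gives > 25000 nM in this assay.

Each of these three values is a limit of the assay, not a number. Compound 1 therefore stands where every measured compound stands, at the limit of > 25000 nM in this assay, at which 3 of the 3 values shown sit. Within the data shown here, no pair among the measured compounds differs in a single place, so no measured step is available to guide the next move.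

Compound 4, `CN1CCc2c(sc(NC(=O)Nc3ccc(Cl)cc3)c2C(N)=O)C1`, has not yet been measured. It differs from compound 1 in one place: hydrogen in place of tert-butoxycarbonyl on a saturated chain carbon bound to an amine nitrogen in a ring. Among the measured compounds shown here, since all measured values sit at the limit, the data offer no step whose size or direction can be borrowed, and the change itself is not tied to any measured effect here. The step from compound 1 to compound 4 is expected to be a number no higher from compound 1 to compound 4 (the limit leaves the size open), that is, no movement beyond the scatter. Compound 4 is expected to give 25000 nM in this assay, within 6000 nM to 25000 nM, most probably reported again as a limit.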

Compound 4, half-maximal effective concentration: 4700 nM
Estimate against measurement, compound 4: 5.3-fold (0.73 log units) above, and the stated range ends above it.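

In this assay the change brings an at least 5.3-fold lower number from compound 1 to compound 4 (0.72 log units; beyond the scatter) and provides the only step that can be read among the compounds shown. It shows that the place on the core of compound 1 where tert-butoxycarbonyl is lost can move the read-out beyond the scatter, and that (tert-butoxycarbonyl)methyl can be cut back to methyl with a lower number as the result. The full size of the step remains unknown, as the value for compound 1 is a limit of the assay and not a number, and compound 4 alone stands off that limit: the limit of > 25000 nM in this assay, at which 3 of the 4 values shown sit.

On these data alone, whether a carboxylic acid in place of tert-butoxycarbonyl, or a propyl chain in place of methyl, would keep the number near that of compound 4 remains open. A single step also cannot show a trend across groups at this place.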